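From a Silent Compound to a Fluoro Analogue

The compounds below may be only part of what the source reports. "The series", "measured", "known", "first", "only" and "open" are said of these compounds alone.

Of the compounds shown here, three have been tested in a functional assay on HeLa cells (Homo sapiens) for inhibition, read by MTT assay, with a stated time of 72 h (on this read-out higher numbers stand for weaker inhibition and lower numbers for stronger inhibition), and only one of them gives a real number. Compound 1 (`COc1cc(OC)c(OC)cc1/C=C/C(=O)c1cc(Cc2ccccc2)cc(Cc2ccccc2)c1`) gives 26900 nM as a measured value. Compound 2 (`COc1cc(OC)c(OC)cc1/C=C/C(=O)c1ccc(-c2c[nH]cn2)cc1`) gives > 150000 nM and this is a limit of the assay, not a number. Compound 3 (`COc1cc(OC)c(-c2cc(=O)c3cc(Cl)ccc3o2)cc1OC`) gives > 150000 nM and this too is a limit. Compound 2 therefore stands at the limit of > 150000 nM in this assay, at which 2 of the 3 values shown sit, with no number of its own.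

Compound 4 (`COc1cc(OC)c(OC)cc1/C=C/C(=O)c1ccc(F)cc1`) has not yet been measured. It differs from compound 2 in one place: fluoro in place of 1H-imidazol-4-yl on an aromatic carbon, para to a large group (fluoro in place of 1H-imidazol-4-yl on an aromatic carbon). For the measured compounds named here, no measured pair shows this kind of change, so the size of the step can only be judged indirectly. Compound 2 shares much of its structure with compound 1, which reaches 26900 nM in this assay and shows that a measurable value is possible for a close relative. A modest move towards stronger inhibition is therefore expected, although compound 4 may also stay at the limit. The estimated change is an at least 2.5-fold lower number from compound 2 to compound 4 (0.39 log units; beyond the scatter) and it remains a rough expectation. In this assay the expected value for compound 4 is 60000 nM with an estimated range from 15000 nM to 150000 nM as its likely span.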

Compound 4, half-maximal inhibitory concentration: 28600 nM
For compound 4 the middle estimate is 2.1-fold (0.32 log units) above the measured one, within the range that was stated.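

In this assay, the change from 1H-imidazol-4-yl to fluoro, on an aromatic carbon para to a large group, gives an at least 5.2-fold lower number from compound 2 to compound 4 (0.71 log units; beyond the scatter). For the compounds shown here, until now no pair differing in one place could be read, and this pair is the first to show that the group at this single position can separate a compound with a measurable value from one without. The true size of the step stays unknown, because compound 2 has only a limit of the assay and no number of its own: the limit of > 150000 nM in this assay, at which 2 of the 4 values shown sit.

The swap also changes several things at once, as a five-membered aromatic ring with a hydrogen-bond donor and a hydrogen-bond acceptor leaves and a single fluorine enters, so the compounds shown cannot tell which of these differences matters. Going by these compounds alone, they also leave open how an amine, a carboxylic acid or a longer chain at this same position would read out, and whether fluoro is special here or only one of many groups that would give a measurable value.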